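Cytotoxicity of a methylenecyclopropane nucleoside series

This account rests on a few compounds, and the source may have more. Where it says the series, first, only, none or still open, it means among the compounds named here.

Compound 1, `Nc1nc(NCc2ccccc2)c2ncn(/C=C3/CC3(CO)CO)c2n1`, gives > 300000 nM in an ADME assay on HFF cells (Homo sapiens) for cytotoxicity, with a stated time of 8 days; a lower number here means that less compound is tolerated, a higher number that more compound is tolerated; this is a limit of the assay.
Compound 2, `CC(C)Nc1nc(N)nc2c1ncn2/C=C1/CC1(CO)CO`, gives > 300000 nM in this assay; this too is a limit.
Compound 3, `CCCCCCSc1nc(N)nc2c1ncn2/C=C1/CC1(CO)CO`, gives > 300000 nM in this assay, again a limit.

Compound 1 therefore stands at the upper edge of what this assay reports, and no number separates it from its two neighbours. Compound 4, `CCCCNc1nc(N)nc2c1ncn2/C=C1/CC1(CO)CO`, differs from compound 1 in this way: propyl in place of phenyl on a saturated chain carbon bound to a nitrogen on an aromatic ring. The steps already measured that bear on this change are a step that the two limits leave unreadable from compound 1 to compound 2, a step that the two limits leave unreadable from compound 1 to compound 3 and a step that the two limits leave unreadable from compound 2 to compound 3; none of them can be read, because of the limit of > 300000 nM in this assay, at which 3 of the 3 values shown sit. With every measured value sitting at that limit, the step to compound 4 is expected to show no change beyond the scatter, and compound 4 is expected to sit at the limit as well, with an estimated step of a number no higher from compound 1 to compound 4 (the limit leaves the size open). The estimate for compound 4 is 300000 nM, with a range from 100000 nM to 1000000 nM.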

Compound 4, half-maximal cytotoxic concentration: > 300000 nM
Compound 4 ended at the assay's limit; the forecaster's own chance of this, stated with the estimate: 85%; the middle value lies on the limit itself.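

In this assay, going by these compounds alone, no step from compound 1, compound 2 or compound 3 to compound 4 can be read, because all four values are limits: the limit of > 300000 nM in this assay, at which 4 of the 4 values shown sit.
The compounds shown leave open whether their side groups differ in cytotoxicity at all, and at what level any of them harms these cells.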